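The compounds below may be only part of what the source reports. "The series", "measured", "known", "first", "only" and "open" are said of these compounds alone.

In a functional assay on HT-29 cells (Homo sapiens) for inhibition (on this read-out higher numbers stand for weaker inhibition and lower numbers for stronger inhibition), compound 1 (`COc1ccc(/C=C\c2ccc3ccccc3c2)cc1N`) gives 1820 nM and compound 2 (`COc1cc(/C=C\c2ccc3ccccc3c2)cc(N)c1OC`) gives 330 nM. For the measured compounds named here, the one measured step between them is a 5.5-fold lower number from compound 1 to compound 2 (0.74 log units; beyond the scatter). In this assay, compound 3 (`COc1c(N)cc(/C=C/c2ccc3ccccc3c2)cc1N`) stands at > 5000 nM, which is a limit and not a number. Compound 4 (`COc1c(N)cc(/C=C\c2ccc3ccccc3c2)cc1N`) differs from compound 3 thus: the two compounds have the same atoms and bonds and differ only in configuration as drawn: 1 of 1 stereo elements differ; a double bond is drawn E in compound 3 and Z in compound 4. Going by the values given here, no measured step covers this change directly, since the only one swaps hydrogen for methoxy. Yet both numbers so far come from compounds with the double bond drawn Z, as in compound 4: compound 1 at 1820 nM and compound 2 at 330 nM. The expected change is an at least 10-fold lower number from compound 3 to compound 4 (1.00 log units; beyond the scatter), a lower number beyond the scatter. For compound 4 the estimated value is 500 nM, with an expected range from 80 nM to 3000 nM.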

Compound 4, half-maximal inhibitory concentration: > 5000 nM
Compound 4: no number, only a limit; the forecaster's own chance of this, stated with the estimate: 12%; middle value at least 10-fold (1.00 log units) from the limit.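

Amino in place of methoxy on an aromatic carbon gives an at least 15-fold higher number from compound 2 to compound 4 (1.18 log units; beyond the scatter), and an added amino group gives an at least 2.7-fold higher number from compound 1 to compound 4 (0.43 log units; beyond the scatter). Starting from compound 1, methoxy and amino at this place therefore move the number in opposite directions. The change of configuration itself cannot be read, since compound 3 and compound 4 both sit at a limit: the limit of > 5000 nM in this assay, at which 2 of the 4 values shown sit.

Going by these compounds, how far compound 4 lies past that limit stays open, and so does any effect of the double-bond configuration. Also open, on these data alone, is whether a hydroxyl or an ethoxy group at this place would follow methoxy or amino.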